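The source may hold more compounds than are shown below. What is called first, only, known or untested is meant among the compounds shown, and "the series" means these compounds.

Measured compounds:
- Compound 1, `COc1ccccc1C1C(C(=O)C(C)(C)C)=C(O)C(=O)N1c1ccc(-c2ccon2)cc1`: 2.6 h
- Compound 2, `CC(C)(C)C(=O)C1=C(O)C(=O)N(c2ccc(-c3ccon3)cc2)C1c1ccccc1OCCO`: 2.1 h
- Compound 3, `COc1ccccc1C1C(C(=O)C(C)C)=C(O)C(=O)N1c1ccc(-c2ccsc2)cc1`: 6.1 h

All three were tested in an ADME assay on the whole organism (Rattus norvegicus) for metabolic stability; on this read-out lower numbers stand for a shorter-lived compound and higher numbers for a longer-lived compound. In this assay compound 1 gives 2.6 h, compound 2 gives 2.1 h and compound 3 gives 6.1 h. Compound 3 stands highest of the three; its gap to compound 1 and to compound 2 is beyond the usual scatter in both cases.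

Compound 2 differs from compound 1 in one place, (hydroxymethyl in place of hydrogen on a saturated chain carbon bound to an oxygen on an aromatic ring). This change produced a 1.2-fold lower number from compound 1 to compound 2 (0.09 log units; within the scatter), a step that stays within the scatter of repeated measurements, so it cannot be said to have altered the half-life in any real way.

The unmeasured compound 4, `CC(C)C(=O)C1=C(O)C(=O)N(c2ccc(-c3ccsc3)cc2)C1c1ccccc1OCCO`, carries the very same change relative to compound 3: hydroxymethyl in place of hydrogen on a saturated chain carbon bound to an oxygen on an aromatic ring. The place of the change is the same in both pairs, so it is the same change made on a different core. How the core of compound 3 differs from that of compound 1 is not broken down here.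

Among the measured compounds shown here, since the only earlier example of this change gave a 1.2-fold lower number from compound 1 to compound 2 (0.09 log units; within the scatter), a step of similar, small size is expected from compound 3 to compound 4 in this assay, namely a 1.2-fold lower number from compound 3 to compound 4 (0.09 log units; within the scatter). Compound 4 is therefore expected to give about 5 h, with a likely range from 2.5 h to 10 h.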

Compound 4, half-life: 1 h
Beside the measured number, compound 4's estimate is 5.0-fold (0.70 log units) above it; measured number below the stated range.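

On the core of compound 3, swapping 2-methoxyphenyl for 2-(2-hydroxyethoxy)phenyl gave a 6.1-fold lower number from compound 3 to compound 4 (0.79 log units; beyond the scatter) in this assay, so here the change shortened the measured half-life by more than the usual scatter. The size of this step therefore did not carry over from one core to the other, and the earlier pair alone was a poor guide to the new one: the same change on two cores in this assay, a 1.2-fold lower number (0.09 log units; within the scatter) from compound 1 to compound 2 and a 6.1-fold lower number (0.79 log units; beyond the scatter) from compound 3 to compound 4, 4.9-fold (0.69 log units) apart, beyond the scatter of two such steps. Among the compounds shown here, this shows that the effect of the change depends on the core it is made on, at least for these two pairs, but it does not show why, and with only two cores it gives no rule for how the change will behave on any other core.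

The compounds shown leave open which of the differences between the core of compound 1 and the core of compound 3 separates the two steps, a question that hybrids combining parts of both cores could address. They also leave open whether a longer chain such as 3-hydroxypropoxy, or an amine as in 2-aminoethoxy, would give a step like that of compound 4 on the core of compound 3.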